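Halogen swap on the pyridine ether: fluoro to chloro

The source may hold more compounds than are shown below. What is called first, only, known or untested is meant among the compounds shown, and "the series" means these compounds.

Two compounds of the series have numbers in an assay on brain for binding affinity to Neuronal acetylcholine receptor; alpha4/beta2 (Rattus norvegicus), read by radioligand binding; a higher number here means a weaker inhibitor, a lower number a stronger inhibitor. Compound 1 `c1ccc(-c2ccc(OC[C@@H]3CCN3)cn2)cc1` gives 2.3 nM in this assay, and compound 2 `Fc1cncc(OC[C@@H]2CCN2)c1` gives 0.076 nM. Compound 2 therefore stands at the lowest of the two numbers, with compound 1 sitting a long way higher, a gap well beyond the scatter.

The next compound, compound 3 `Clc1cncc(OC[C@@H]2CCN2)c1`, is not yet measured. It differs from compound 2 in one place: chloro in place of fluoro on an aromatic carbon, on an aromatic carbon of a six-membered aromatic ring with one nitrogen, two atoms from the ring nitrogen. For the measured compounds named here, no pair of measured compounds shows this kind of exchange, so its size cannot be read from the numbers at hand; the expectation is a step of no more than the scatter, in either direction.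

For compound 3 in this assay the estimate is 0.1 nM, with a range from 0.03 nM to 0.4 nM, which corresponds to an expected step of a 1.3-fold higher number from compound 2 to compound 3 (0.12 log units; within the scatter).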

Compound 3, inhibition constant: 0.042 nM
The estimate for compound 3 lay 2.4-fold (0.38 log units) above the measured number, and the stated range covers the measured number.
By their numbers in this assay, from the lowest: compounds 3 and 2 (each within the scatter of the next); then compound 1.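

In this assay, for the compounds shown here, chloro in place of fluoro on an aromatic carbon, two atoms from the ring nitrogen, gives a 1.8-fold lower number from compound 2 to compound 3 (0.26 log units; within the scatter) and this is the first exchange that can be read from a measured pair. At this position, the two halogens cannot be told apart: compound 2 and compound 3 stand within the scatter of each other, and neither ranks above the other. Nothing at hand bears on the reason for this result.

Still open, going by these compounds, is whether bromo, methyl, nitrile, methoxy or an amine at this place would give a number close to those of compound 2 and compound 3. Also open, on these data alone, is whether the same exchange would read alike on other substituted versions of the shared core.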